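The source may hold more compounds than are shown below. What is called first, only, known or untested is meant among the compounds shown, and "the series" means these compounds.

Three compounds of the series have numbers in a functional assay on CHO cells for agonist activity at Alpha-1A adrenergic receptor (Homo sapiens), read by FLIPR and calcium flux; a higher number here means a larger maximal response, a lower number a smaller maximal response. Compound 1 `COCc1ccccc1C1Cc2nccn2C1` gives 77%, compound 2 `Fc1ccccc1C1Cc2nccn2C1` gives 63%, and compound 3 `Clc1ccccc1C1CCc2nc[nH]c2C1` gives 60%. Compound 2 stands second highest of the three: its nearest neighbour is compound 3, whose number lies within the scatter of it, and its furthest is compound 1, whose number lies beyond the scatter. Among the compounds with values here, the single one-place step measured so far, a number 14 percentage points lower from compound 1 to compound 2 (beyond the scatter), accounts for that gap.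

Compound 4 `FC(F)Oc1ccccc1C1Cc2nccn2C1` is still to be measured in this assay. It differs from compound 2 in one place: difluoromethoxy in place of fluoro on an aromatic carbon. The measured step from compound 1 to compound 2 bears on this change, as it also exchanged a group holding a carbon and an oxygen for fluoro and brought a modest fall. The change to compound 4 runs the other way, fluoro giving way to a group of 4 heavy atoms that again holds an oxygen, so a step of comparable size upward is expected, set somewhat short of a full return because the entering group is not the one that left in a number 14 percentage points lower from compound 1 to compound 2 (beyond the scatter). For compound 4 the expected value in this assay is 72%, in a range from 60% to 84%, which means an expected step of a number 9 percentage points higher from compound 2 to compound 4 (within the scatter).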

Compound 4, largest response reached (Emax), in percent of the reference or control that the assay uses: 75%
Compound 4: the middle estimate sits 3 percentage points below what was measured; low and high end bracket the measured number.
By their numbers in this assay, from the lowest: compounds 3 and 2 (each within the scatter of the next); then compounds 4 and 1 (each within the scatter of the next).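

In this assay, the position on the aromatic carbon now has a second step beyond the scatter: a number 12 percentage points higher from compound 2 to compound 4 (beyond the scatter). Together with the earlier a number 14 percentage points lower from compound 1 to compound 2 (beyond the scatter), this places fluoro below both oxygen-holding groups at this position, so the lower response of compound 2 no longer rests on a single comparison with methoxymethyl. The step of a number 2 percentage points lower from compound 1 to compound 4 (within the scatter) shows that difluoromethoxy and methoxymethyl cannot be told apart in this read-out despite their different atoms, and nothing shown gives a reason for the rise with difluoromethoxy.

The three groups leave open whether the higher response follows the oxygen, the number of heavy atoms or some other feature, since both higher-response groups differ from fluoro in more than one respect; a methoxy group, an ethyl group and an amine at the same place would help separate these readings. Going by these compounds, it also remains open whether the same order among fluoro, methoxymethyl and difluoromethoxy would hold on another core or at another place on the aromatic ring.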